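The source may hold more compounds than are shown below. What is called first, only, known or untested is meant among the compounds shown, and "the series" means these compounds.

Measured so far:
Compound 1 `Cc1n[nH]c(C(=O)O)c1Cc1cccc(C(N)=O)c1` gives 8%
Compound 2 `Cc1n[nH]c(C(=O)O)c1Cc1ccc(C#N)cc1` gives 0%
Compound 3 `Cc1nn(C)c(C(=O)O)c1Cc1cccc(-c2ccc(F)cc2)c1` gives 5%

All three were tested in an assay on isolated protein for inhibition of 2-Hydroxyacid oxidase 2 (Homo sapiens), tested at 1 uM; on this read-out lower numbers stand for a weaker effect and higher numbers for a stronger effect at the one concentration tested. None of them reaches a notable effect there. Compound 2 shows no inhibition at all with 0%, and the numbers of compound 3 and compound 1 sit within the usual scatter of that, so the three compounds cannot be told apart on this read-out. For the measured compounds named here, no pair among them differs in a single place, so nothing is known here about how any one change moves the numbers.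

The next compound, compound 4 `Cc1n[nH]c(C(=O)O)c1Cc1ccc(C(=O)O)cc1`, has not yet been measured in this assay. Its structure differs from compound 2 in one place: carboxy in place of cyano on an aromatic carbon. Since every measured compound, including compound 2 with 0%, lies near the bottom of the scale, the step from compound 2 to compound 4 is expected to be small, a number 5 percentage points higher from compound 2 to compound 4 (within the scatter), and not beyond the scatter in either direction. Compound 4 is thus estimated to give 5%, somewhere between -5% and 20%.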

Compound 4, a percentage reported as inhibition, at one concentration (the size of the read-out at that concentration, not a potency): 3%
Estimate against measurement, compound 4: 2 percentage points above; the range from low to high includes it.
By their numbers in this assay, from the lowest: compounds 2, 4, 3 and 1 (each within the scatter of the next).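

For the compounds shown here, this is the first comparison in the set that changes only one place. In this assay, putting carboxy in place of cyano on an aromatic carbon, para to a large group, gives a number 3 percentage points higher from compound 2 to compound 4 (within the scatter). This exchange therefore leaves the two compounds indistinguishable at the one concentration tested, and no measurement is available to explain that result.

Both compounds lie near the bottom of the scale, so this single step cannot show whether the position matters at all or whether the core of compound 2 simply shows little effect at this concentration. Going by these compounds, it also remains open whether a different group at this position, such as an amine or a methoxy group, would give a number beyond the scatter.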